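The compounds below may be only part of what the source reports. "The series", "measured", "known", "first", "only" and "open" are said of these compounds alone.

Compound 1 `O=C(N/N=C/c1ccccc1)Nc1ccc(Oc2ccnc3[nH]ccc23)c(F)c1`: 7940 nM
Compound 2 `O=C(N/N=C/c1cccc(Br)c1)Nc1ccc(Oc2ccnc3[nH]ccc23)c(F)c1`: 4020 nM
Compound 3 `O=C(N/N=C/c1ccc([N+](=O)[O-])cc1)Nc1ccc(Oc2ccnc3[nH]ccc23)c(F)c1`: 150 nM

In a functional assay on PC-3 cells (Homo sapiens) for antiproliferative activity, read by MTT assay, with a stated time of 72 h (a lower number here means a stronger inhibitor, a higher number a weaker inhibitor), compound 3 stands lowest of the three at 150 nM. Compound 4 `O=C(N/N=C/c1ccc(O)cc1)Nc1ccc(Oc2ccnc3[nH]ccc23)c(F)c1` departs from it by hydroxy in place of nitro on an aromatic carbon, para to a large group. Two large measured steps bear on this change, a 53-fold lower number from compound 1 to compound 3 (1.72 log units; beyond the scatter) and a 27-fold lower number from compound 2 to compound 3 (1.43 log units; beyond the scatter), while a 2.0-fold lower number from compound 1 to compound 2 (0.30 log units; within the scatter) stays within the scatter. Within the data shown here, no hydroxy compound has been measured, so how much of the gain survives is open. With the nitro gone, a large step towards a higher number is expected, though probably not all the way back: a 13-fold higher number from compound 3 to compound 4 (1.12 log units; beyond the scatter). Compound 4 is estimated at 2000 nM, within an expected range of 300 nM to 9000 nM.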

Compound 4, half-maximal inhibitory concentration: 2780 nM
For compound 4 the middle estimate is 1.4-fold (0.14 log units) below the measured one; low and high end bracket the measured number.
By their numbers in this assay, from the lowest: compound 3; then compounds 4, 2 and 1 (each within the scatter of the next, the first and the last beyond it).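

In this assay, a group at this place does not by itself carry the gain of compound 3: hydroxy in place of nitro loses most of it (a 19-fold higher number from compound 3 to compound 4 (1.27 log units; beyond the scatter)). Only a modest gain over the unsubstituted compound remains (a 2.9-fold lower number from compound 1 to compound 4 (0.46 log units; beyond the scatter)), and the 4-hydroxyphenyl group stays within the scatter of 3-bromophenyl (a 1.4-fold lower number from compound 2 to compound 4 (0.16 log units; within the scatter)). Of the two groups at this place, then, only nitro gives the large step. As far as these compounds go, whether an amine, a nitrile or a methoxy group there would hold the gain stays open, as does whether nitro elsewhere on the ring would. No measurement at hand explains the difference between nitro and hydroxy.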